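A few compounds are considered here, and "the series" means these few. Any claim that something is new, unique, unknown or untested is made for them only; others in the source may bear on it.

Measured so far, in an ADME assay for inhibition of phosphatidylcholine:ceramide cholinephosphotransferase 1 (Homo sapiens), read by mass spectrometry, with stated times of 60 min and 30 min; on this read-out higher numbers stand for weaker inhibition and lower numbers for stronger inhibition:
- compound 1, `CN(Cc1cc(C(F)(F)F)cc(C(F)(F)F)c1)C(=O)c1c(OCCCC(F)(F)F)c2ccccc2n(C)c1=O`: 25000 nM
- compound 2, `CN(Cc1cc(C(F)(F)F)cc(C(F)(F)F)c1)C(=O)c1c(OCCCC2CCN(C(=O)OC3(C)CC3)CC2)c2cccnc2n(C)c1=O`: 850 nM
- compound 3, `COc1cc(CN(C)C(=O)c2c(OCCCC3CCN(C(=O)OC4(C)CC4)CC3)c3cccnc3n(C)c2=O)cc(OC)c1`: 18000 nM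

Compound 1 stands at the highest number of the three. Compound 3 sits nearest to it, within the scatter, so the two cannot be ordered. Compound 2 stands furthest, beyond the scatter, with a markedly lower number.

Compound 4, `CN(Cc1cc(C(F)(F)F)cc(C(F)(F)F)c1)C(=O)c1c(N2CCCCC2)c2ccccc2n(C)c1=O`, is not yet measured. It differs from compound 1 in one place: piperidin-1-yl in place of 4,4,4-trifluorobutoxy on an aromatic carbon. Within the data shown here, no step between measured compounds covers this change, so only the spread among compounds 1 to 3 guides the expectation. The single large move in the set belongs to compound 2, which carries a long chain ending in a ring system, while compound 4 loses its chain entirely and gains a ring set directly on the core.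

Compound 4 is therefore expected to stay close to compound 1, with a step of a 1.2-fold higher number from compound 1 to compound 4 (0.08 log units; within the scatter) that lies within or only just beyond the scatter, in the direction of weaker inhibition if anything. The estimate for compound 4 in this assay is 30000 nM, with a range from 8000 nM to 100000 nM.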

Compound 4, half-maximal inhibitory concentration: > 100000 nM
Compound 4: only a limit was reported (the forecaster's own chance of this, stated with the estimate: 30%); middle value at least 3.3-fold (0.52 log units) from the limit.
By their numbers in this assay, from the lowest: compound 2; then compounds 3 and 1 (each within the scatter of the next). At a limit, above all of these: compound 4.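

In this assay, among these compounds, the aromatic carbon opposite the ring nitrogen does not tolerate every group: piperidin-1-yl in place of 4,4,4-trifluorobutoxy gives an at least 4.0-fold higher number from compound 1 to compound 4 (0.60 log units; beyond the scatter), the only one-place step so far. For compound 4, > 100000 nM is a limit of the assay and not a number, so the step has a lower bound but no known size: the limit of > 100000 nM in this assay, at which 1 of the 4 values shown sits. On this single pair, a ring set directly on the core through nitrogen reads weaker than an open chain joined through oxygen.

This pair cannot separate the effect of the ring from that of the linking atom. A dimethylamino group, a morpholine ring or an unfluorinated butoxy chain at this carbon would bear on both questions.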